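Removing the hydroxy from compound 3

This account rests on a few compounds, and the source may have more. Where it says the series, first, only, none or still open, it means among the compounds named here.

In a functional assay on A549 cells (Homo sapiens) for antiproliferative activity, read by MTT assay, with a stated time of 48 h (a lower number here means a stronger inhibitor, a higher number a weaker inhibitor), compound 1 (`O=C(CCCCCC(=O)Nc1ccc(O)c(C(=O)Nc2ccccc2)c1)NO`) gives 14600 nM and compound 2 (`O=C(CCCCCC(=O)Nc1ccc(O)c(C(=O)Nc2ccc(F)c(Cl)c2)c1)NO`) gives 21100 nM, a 1.4-fold higher number from compound 1 to compound 2 (0.16 log units; within the scatter). Compound 3 (`C#Cc1cccc(NC(=O)c2cc(NC(=O)CCCCCC(=O)NO)ccc2O)c1`) stands highest of the three at 76200 nM, with a 5.2-fold higher number from compound 1 to compound 3 (0.72 log units; beyond the scatter) and a 3.6-fold higher number from compound 2 to compound 3 (0.56 log units; beyond the scatter). Compound 4 (`C#Cc1cccc(NC(=O)c2cccc(NC(=O)CCCCCC(=O)NO)c2)c1`) has hydrogen in place of hydroxy on an aromatic carbon, ortho to a large group and para to a large group: hydrogen in place of hydroxy on an aromatic carbon. Among the compounds with values here, no measured step touches this hydroxy, so the steps above bear on it only as a guide to size. From the compounds shown here alone, the direction stays open, with a modest move to a lower number expected since compound 3 sits at the top at 76200 nM. The expected step is a 1.5-fold lower number from compound 3 to compound 4 (0.18 log units; within the scatter). For compound 4 the estimated value is 50000 nM, with an expected range of 15000 nM to 150000 nM.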

Compound 4, half-maximal inhibitory concentration: 37600 nM
For compound 4 the middle estimate is 1.3-fold (0.12 log units) above the measured one; measured number inside the range.
By their numbers in this assay, from the lowest: compounds 1, 2 and 4 (each within the scatter of the next, the first and the last beyond it); then compound 3.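

In this assay, within the data shown here, hydrogen in place of hydroxy gives a 2.0-fold lower number from compound 3 to compound 4 (0.31 log units; beyond the scatter) and this is the first measured change at this position on the aromatic carbon. The step is modest and favours the compound without the hydroxy, so activity in this assay does not depend on the hydroxy when the 3-ethynylphenyl amide is present. No measurement here accounts for the step.

From the compounds shown here alone, whether the same replacement holds with phenyl or 3-chloro-4-fluorophenyl on the amide nitrogen remains open. Also open, going by these compounds, is how a methoxy, an amine or a fluorine would compare with hydroxy at this position.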